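The source may report more compounds than this note shows. Statements on the series, on what has been measured and on what is new or still open speak of the compounds shown alone.

Compound 1, `CO[C@@]1(C(=O)O)C=C[C@@H](NC(C)=O)[C@H]([C@H](O)[C@H](O)CO)O1`, is the anchor of this short series. In an assay on HEK293 cells for inhibition of sialidase-3 (Homo sapiens), read by fluorescence, with a stated time of 1 h (a higher number here means a weaker inhibitor, a lower number a stronger inhibitor), compound 1 gives > 1000000 nM, which is a limit of the assay rather than a number. Compound 2, `CCS[C@@]1(C(=O)O)C=C[C@@H](NC(C)=O)[C@H]([C@H](O)[C@H](O)CO)O1`, carries ethylsulfanyl in place of methoxy on a saturated ring carbon. In this assay compound 2 gives > 1000000 nM, again a limit. The step from compound 1 to compound 2 is thus a step that the two limits leave unreadable from compound 1 to compound 2. For the measured compounds named here, the only evidence on the measured steps is the limit of > 1000000 nM in this assay, at which 2 of the 2 values shown sit. Compound 3, `CCO[C@@]1(C(=O)O)C=C[C@@H](NC(C)=O)[C@H]([C@H](O)[C@H](O)CO)O1`, differs from compound 2 by ethoxy in place of ethylsulfanyl on a saturated ring carbon. Going by the values given here, compound 2 stands at a limit, so no measured step offers a readable size that bears on this change, and nothing beyond the scatter can be expected from it. The step from compound 2 to compound 3 is expected to be a step that the limit leaves unreadable from compound 2 to compound 3. Compound 3 is accordingly estimated at 2000000 nM, within a range from 500000 nM to 10000000 nM, and most likely it will again be reported only as a limit.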

Compound 3, half-maximal inhibitory concentration: > 1000000 nM
Compound 3 ended at the assay's limit; the forecaster's own chance of this, stated with the estimate: 85%; the middle value does not contradict the limit.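

In this assay compound 3 gives > 1000000 nM, again a limit of the assay. For the compounds shown here, no step among compound 1, compound 2 and compound 3 can be read. The compounds shown leave open whether methoxy, ethylsulfanyl and ethoxy differ at all in this inhibition: the limit of > 1000000 nM in this assay, at which 3 of the 3 values shown sit.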